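This account rests on a few compounds, and the source may have more. Where it says the series, first, only, none or still open, it means among the compounds named here.

Compound 1 `Oc1ccc(-c2cc(-c3cccs3)cc(-c3cccc(O)c3)n2)cc1`: 780 nM
Compound 2 `Oc1ccc(-c2cc(-c3cccs3)cc(-c3ccc(O)cc3)n2)cc1`: 11700 nM
Compound 3 `Oc1ccc(-c2cc(-c3cccnc3)cc(-c3cccc(O)c3)n2)cc1`: a limit, > 50000 nM

All three were tested in a functional assay on T47D cells (Homo sapiens) for cytotoxicity, read by CCK-8 assay; on this read-out lower numbers stand for stronger inhibition and higher numbers for weaker inhibition. In this assay compound 1 gives 780 nM and compound 2 gives 11700 nM. For compound 3 this assay reports no number but a limit, > 50000 nM, namely (the limit of > 50000 nM in this assay, at which 1 of the 3 values shown sits). The change 4-hydroxyphenyl in place of 3-hydroxyphenyl on an aromatic carbon produced a 15-fold higher number from compound 1 to compound 2 (1.18 log units; beyond the scatter). The two cores differ by pyridin-3-yl in place of thiophen-2-yl on an aromatic carbon, which gave an at least 64-fold higher number from compound 1 to compound 3 (1.80 log units; beyond the scatter).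

Compound 4 `Oc1ccc(-c2cc(-c3cccnc3)cc(-c3ccc(O)cc3)n2)cc1` is not yet measured. It arises from compound 3 by 4-hydroxyphenyl in place of 3-hydroxyphenyl on an aromatic carbon, the same kind of change as that from compound 1 to compound 2, the place differing only in being meta to a pyridin-3-yl group rather than meta to a thiophen-2-yl group. Compound 4 is therefore expected to show a further loss, a step that the limit leaves unreadable from compound 3 to compound 4, since compound 1 to compound 2 gave a 15-fold higher number from compound 1 to compound 2 (1.18 log units; beyond the scatter). Compound 4 is estimated at 300000 nM, between 50000 nM and 2000000 nM, most likely reported only as a limit.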

Compound 4, half-maximal inhibitory concentration: 2030 nM
The estimate for compound 4 lay 150-fold (2.17 log units) above the measured number; the measured number lies below the stated range.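

In this assay, 4-hydroxyphenyl in place of 3-hydroxyphenyl gave an at least 24-fold lower number from compound 3 to compound 4 (1.39 log units; beyond the scatter), so the change did not carry over from the core of compound 1 in direction: the same change on two cores in this assay, a 15-fold higher number (1.18 log units; beyond the scatter) from compound 1 to compound 2 and an at least 24-fold lower number (1.39 log units; beyond the scatter) from compound 3 to compound 4, at least 360-fold (2.56 log units) apart, beyond the scatter of two such steps. Pyridin-3-yl in place of thiophen-2-yl likewise reversed, giving a 5.8-fold lower number from compound 2 to compound 4 (0.76 log units; beyond the scatter): the same change on two cores in this assay, an at least 64-fold higher number (1.80 log units; beyond the scatter) from compound 1 to compound 3 and a 5.8-fold lower number (0.76 log units; beyond the scatter) from compound 2 to compound 4, at least 360-fold (2.56 log units) apart, beyond the scatter of two such steps. The effect of each change thus depends on the other within these four compounds, although compound 3 stands only as a limit, which leaves the exact size of its steps unread, and four compounds give no rule for other cores: the limit of > 50000 nM in this assay, at which 1 of the 4 values shown sits.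

The compounds shown leave open whether this dependence persists with a furan-2-yl or phenyl group in place of the thiophen-2-yl group. They also leave open how a methoxy group or an amine would behave in place of either hydroxyl.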